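This account rests on a few compounds, and the source may have more. Where it says the series, first, only, none or still open, it means among the compounds named here.

Measured compounds in an assay on isolated protein for inhibition of malate dehydrogenase, mitochondrial (Sus scrofa), with stated times of 45 min and 30 min; a higher number here means a weaker inhibitor, a lower number a stronger inhibitor:

Compound 1 `O=S(=O)(Nc1ccc(-c2nc3ccccc3o2)cc1)c1cccs1`, which gives > 63000 nM, a limit of this assay rather than a number.
Compound 2 `O=S(=O)(Nc1ccc2oc(-c3ccccc3)nc2c1)c1ccccc1O`, which gives > 63000 nM, again a limit rather than a number.
Compound 3 `O=S(=O)(Nc1ccc(-c2nc3ccccc3o2)cc1)c1ccccc1Cl`, which gives > 63000 nM, also a limit rather than a number.

All three values therefore sit at the same boundary, as the limit of > 63000 nM in this assay, at which 3 of the 3 values shown sit, records, and none of them is a measured number. Compound 2 thus stands at the limit, with no number of its own to place it against the others.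

Compound 4 `O=S(=O)(Nc1ccc2oc(-c3ccccc3)nc2c1)c1cccc(O)c1` is not yet measured. It differs from compound 2 in one place: 3-hydroxyphenyl in place of 2-hydroxyphenyl on a sulfonyl sulfur. Within the data shown here, of the measured steps, only one changes a group on the same sulfonyl sulfur, and that is a step that the two limits leave unreadable from compound 1 to compound 3. Because both ends of it are limits, its size cannot be read, so it gives no guide to how a change at this position moves the value in this assay.

With no readable step to rest on, no movement beyond the scatter can be foreseen, and the most likely outcome is that compound 4 also returns only a limit. On that basis the expected step that the limit leaves unreadable from compound 2 to compound 4 is essentially none, and compound 4 is estimated at 100000 nM, within a range from 30000 nM to 400000 nM.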

Compound 4, half-maximal inhibitory concentration: > 63000 nM
Compound 4: only a limit was reported (the forecaster's own chance of this, stated with the estimate: 85%); the middle value does not contradict the limit.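

Compound 2 and compound 4 both return limits rather than numbers, so the swap of 2-hydroxyphenyl for 3-hydroxyphenyl gives no step whose size can be read, because both sit at the same boundary: the limit of > 63000 nM in this assay, at which 4 of the 4 values shown sit.

The compounds shown leave open whether any group on the sulfonyl sulfur can bring a readable value in this assay.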